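Swapping tert-butoxy for heptyl on a stable pair

The source may hold more compounds than are shown below. What is called first, only, known or untested is meant among the compounds shown, and "the series" means these compounds.

In an ADME assay on Jejunum (Sus scrofa) for metabolic stability, read by LC-MS, with a stated time of 1 h, tested at 20 uM (a lower number here means that less of the compound is left, a higher number that more of the compound is left), compound 1 `CC(=O)NCCCC[C@H](NC(=O)OC(C)(C)C)C(=O)N[C@@H](CCC(=O)C=[N+]=[N-])C(=O)OC(C)C` gives > 50%, which is a limit and not a number. Compound 2 `CC(=O)NCCCC[C@H](NC(=O)[C@@H]1Cc2ccccc2CN1C(C)=O)C(=O)N[C@@H](CCC(=O)C=[N+]=[N-])C(=O)OC(C)C` gives > 50%, which is likewise a limit. Going by the values given here, no exact figure is therefore available for either compound, and no measured step connects them.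

Compound 3 `CCCCCCCC(=O)N[C@@H](CCCCNC(C)=O)C(=O)N[C@@H](CCC(=O)C=[N+]=[N-])C(=O)OC(C)C` has heptyl in place of tert-butoxy on a carbonyl carbon. No step beyond the scatter is expected in this assay, and no direction is favoured. This expectation rests on compound 1 and compound 2, which share (the limit of > 50% in this assay, at which 2 of the 2 values shown sit). The estimated change is a step that the limit leaves unreadable from compound 1 to compound 3, though the limit on the starting value makes that figure only a rough expectation. For compound 3, the estimated value is 62%, with an expected range from 40% to 85%.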

Compound 3, percent of the compound remaining: > 50%
Compound 3: a limit, no number (the forecaster's own chance of this, stated with the estimate: 60%); the middle value lies beyond the limit too.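

In this assay compound 3 gives > 50%, which is a limit and not a number. Going by these compounds alone, compound 1 also stands at a limit, and no step from compound 1 to compound 3 can be read. The compounds shown leave open whether heptyl and tert-butoxy differ at all in the percent of compound remaining.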